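Acetamido in Place of Ethoxy: Estimating Compound 4

The compounds below may be only part of what the source reports. "The series", "measured", "known", "first", "only" and "open" are said of these compounds alone.

Three compounds have been measured in a functional assay on HL-60 cells (Homo sapiens) for inhibition, read by MTT assay, with a stated time of 72 h; a lower number here means a stronger inhibitor, a higher number a weaker inhibitor:
Compound 1 `Cc1nc(-c2ccccc2)c(C(=O)N2CCN(c3ccccc3F)CC2)o1` gives 147 nM.
Compound 2 `Cc1nc(-c2ccccc2)c(C(=O)N2CCN(c3ccccc3C(F)(F)F)CC2)o1` gives 120 nM.
Compound 3 `CCOc1cccc(N2CCN(C(=O)c3oc(C)nc3-c3ccccc3)CC2)c1` gives 151 nM.

Compound 3 has the highest of the three numbers, but every step to it is small: a 1.0-fold higher number from compound 1 to compound 3 (0.01 log units; within the scatter), and a 1.3-fold higher number from compound 2 to compound 3 (0.10 log units; within the scatter). The three compounds therefore cannot be ranked against one another. Compound 4 `CC(=O)Nc1cccc(N2CCN(C(=O)c3oc(C)nc3-c3ccccc3)CC2)c1` is not yet measured. It differs from compound 3 in one place: acetamido in place of ethoxy on an aromatic carbon.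

For the measured compounds named here, two measured steps bear on this change. The swap of a whole group on the amine nitrogen in the ring, from compound 1 or compound 2 to compound 3, moved the number only within the scatter, and the change of one group on an aromatic carbon, a 1.2-fold lower number from compound 1 to compound 2 (0.09 log units; within the scatter), did likewise. Since all three measured steps, including changes larger than the present one, stayed within the scatter, the expected step is a 1.0-fold lower number from compound 3 to compound 4 (0.00 log units; within the scatter), that is, none beyond the scatter in either direction. Compound 4 is therefore estimated at 150 nM, with a range of 70 nM to 320 nM.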

Compound 4, half-maximal inhibitory concentration: 329 nM
Estimate against measurement, compound 4: 2.2-fold (0.34 log units) below; measured number outside the range, above it.
By their numbers in this assay, from the lowest: compounds 2, 1 and 3 (each within the scatter of the next); then compound 4.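

In this assay, for the compounds shown here, the group on the aromatic carbon meta to a large group is the first place in this set where a change moves the number beyond the scatter, with a 2.2-fold higher number from compound 3 to compound 4 (0.34 log units; beyond the scatter) as a modest step toward a weaker inhibitor. The two swaps of the whole group on the amine nitrogen point the same way, with a 2.2-fold higher number from compound 1 to compound 4 (0.35 log units; beyond the scatter) and with a 2.7-fold higher number from compound 2 to compound 4 (0.44 log units; beyond the scatter) as well, so 3-acetamidophenyl sets this compound apart from the other three, which stay within the scatter of one another. Acetamido brings a hydrogen-bond donor that ethoxy lacks, but no measurement shown explains the step.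

Open, from the compounds shown here alone, is whether an amine or a carboxylic acid on the same aromatic carbon would shift the number as far. Also open, going by these compounds, is whether acetamido elsewhere on that ring would do the same.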